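Chloro for fluoro in a series sitting at the assay limit

This account rests on a few compounds, and the source may have more. Where it says the series, first, only, none or still open, it means among the compounds named here.

Values so far in a toxicity assay on HCT-116 cells (Homo sapiens) for cytotoxicity, read by MTT assay; on this read-out higher numbers stand for weaker inhibition of growth and lower numbers for stronger inhibition of growth:
compound 1, `C/C(=N\Nc1nc(-c2ccc(Cl)cc2)cs1)c1sc(C)nc1C`: > 100 ug/mL, a limit of the assay
compound 2, `C/C(=N\Nc1nc(-c2ccccc2)cs1)c1sc(-c2ccccc2)nc1C`: > 100 ug/mL, a limit of the assay
compound 3, `C/C(=N\Nc1nc(-c2ccc(F)cc2)cs1)c1sc(-c2ccccc2)nc1C`: > 100 ug/mL, a limit of the assay

Compound 3 stands at the limit of this assay; its value is a limit, not a number. All values shown sit there (the limit of > 100 ug/mL in this assay, at which 3 of the 3 values shown sit). Compound 4, `C/C(=N\Nc1nc(-c2ccc(Cl)cc2)cs1)c1sc(-c2ccccc2)nc1C`, differs from compound 3 by chloro in place of fluoro on an aromatic carbon. Going by the values given here, the one measured single-change step, a step that the two limits leave unreadable from compound 2 to compound 3, is itself unreadable, both ends being limits; no measured step bears on a chloro for fluoro swap. Compound 4 is expected to stay at the same limit, with the estimated step that the limit leaves unreadable from compound 3 to compound 4 showing nothing beyond the scatter. For compound 4 the estimate is 150 ug/mL, with a range of 80 ug/mL to 400 ug/mL, most likely reported only as a limit.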

Compound 4, concentration for 50% growth inhibition: > 100 ug/mL
Compound 4 ended at the assay's limit (the forecaster's own chance of this, stated with the estimate: 90%); the middle value is on the limit's open side.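

In this assay compound 4 gives > 100 ug/mL, a limit of the assay, so its steps from compound 1, compound 2 and compound 3 cannot be read: the limit of > 100 ug/mL in this assay, at which 4 of the 4 values shown sit.

The compounds shown leave open whether any change among them alters growth inhibition, as none gives a readable number in this assay.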